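Cell Tolerance When a Phenyl Group Enters

The source may hold more compounds than are shown below. What is called first, only, known or untested is meant among the compounds shown, and "the series" means these compounds.

Going by the values given here, only two compounds have numbers so far. In an ADME assay on HepG2 2.2.15 cells (Homo sapiens) for cytotoxicity (a higher number here means that more compound is tolerated, a lower number that less compound is tolerated), compound 1 `O=CCc1c(-c2ccccc2Cl)c2cc(Cl)ccc2[nH]c1=O` gives 120000 nM as its measured value. Compound 2 `CC12CCC(C(=O)OCCc3c(-c4ccccc4Cl)c4cc(Cl)ccc4[nH]c3=O)(OC1=O)C2(C)C` gives > 1800000 nM as its result, and this is a limit of the assay, not a number. On these data alone, the exact standing of compound 2 therefore remains unknown.

Compound 3 `O=C(OCCc1c(-c2ccccc2Cl)c2cc(Cl)ccc2[nH]c1=O)c1ccccc1` keeps the shared core and differs from compound 2 by a group of 6 heavy atoms (6 carbon; one six-membered aromatic ring of carbon only) in place of a group of 11 heavy atoms (9 carbon, 2 oxygen; one five-membered non-aromatic ring of carbon only, one five-membered non-aromatic ring with 1 hetero atom), on a carbonyl carbon alone. Among the compounds with values here, no measured pair shows what such an exchange does, so any forecast here is loose. A moderate fall in the tolerated concentration seems the likeliest outcome, of a size beyond the usual scatter, though compound 3 could also reach the limit of the assay. Within the data shown here, the only exact number, compound 1 at 120000 nM in this assay, anchors the low side of this expectation. The estimated change is an at least 3.0-fold lower number from compound 2 to compound 3 (0.47 log units; beyond the scatter) and carries real uncertainty. For compound 3 the expected value is 600000 nM with an estimated range from 150000 nM to 2000000 nM overall.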

Compound 3, half-maximal cytotoxic concentration: 43000 nM
Compound 3: the middle estimate sits 14-fold (1.14 log units) above what was measured, outside the stated range (below it).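

In this assay, phenyl on the carbonyl carbon, in place of the group of 11 heavy atoms, gives an at least 41-fold lower number from compound 2 to compound 3 (1.62 log units; beyond the scatter), so what sits at this place matters greatly for how much compound the cells tolerate. Compound 2 holds a limit of the assay and not a number, so this large step marks only a minimum size: the limit of > 1800000 nM in this assay, at which 1 of the 3 values shown sits. With (benzoyloxy)methyl in place of formyl, the result is a 2.8-fold lower number from compound 1 to compound 3 (0.45 log units; beyond the scatter), a modest step, which shows that the carbonyl group with its oxygen does not by itself bring high tolerance, since the phenyl compound sits lower than the formyl compound.

On these data alone, whether the high tolerance of compound 2 depends on the particular group of 11 heavy atoms, or whether phenyl is what brings the number down, remains open, and a cyclohexyl group or a simple methyl on the same carbonyl carbon would help separate these two readings. As far as these compounds go, the exact standing of compound 2 also stays unknown, which leaves the true size of the step to compound 3 open.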